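Compound 3 to compound 4: pyridin-4-yl for phenyl

The source may report more compounds than this note shows. Statements on the series, on what has been measured and on what is new or still open speak of the compounds shown alone.

Values in a functional assay on CCRF-CEM cells (Homo sapiens) for antiproliferative activity; on this read-out lower numbers stand for stronger inhibition and higher numbers for weaker inhibition:
- compound 1 `COc1cc(C(=O)c2sc(-c3ccc(Br)cc3)cc2N)cc(OC)c1OC`: 86 nM
- compound 2 `COc1cc(C(=O)c2sc(-c3ccc(Cl)cc3)cc2N)cc(OC)c1OC`: 70 nM
- compound 3 `COc1cc(C(=O)c2sc(-c3ccccc3)cc2N)cc(OC)c1OC`: 4.5 nM

Compound 3 has the lowest number of the three, clear of both others beyond the scatter. The change under consideration leads to compound 4 `COc1cc(C(=O)c2sc(-c3ccncc3)cc2N)cc(OC)c1OC`: pyridin-4-yl in place of phenyl on an aromatic carbon, (pyridin-4-yl in place of phenyl on an aromatic carbon).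

Going by the values given here, the steps that bear on it alter the same group. Both a 19-fold lower number from compound 1 to compound 3 (1.28 log units; beyond the scatter) and a 16-fold lower number from compound 2 to compound 3 (1.19 log units; beyond the scatter) are large, whereas a 1.2-fold lower number from compound 1 to compound 2 (0.09 log units; within the scatter) stays within the scatter. Among the compounds with values here, compounds 1 and 2 both stand higher than compound 3, but no measured compound has a ring nitrogen in this group, so the size remains uncertain. A rise in this assay is expected, of similar or smaller size. The expected change is a 7.8-fold higher number from compound 3 to compound 4 (0.89 log units; beyond the scatter). For compound 4 the estimate is 35 nM, with an expected range of 8 nM to 200 nM.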

Compound 4, half-maximal inhibitory concentration: 110 nM
Compound 4: middle estimate off by 3.1-fold (0.50 log units), on the low side; the measured number falls inside the stated range.
By their numbers in this assay, from the lowest: compound 3; then compounds 2, 1 and 4 (each within the scatter of the next).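

In this assay, swapping phenyl for pyridin-4-yl gives a large step, a 24-fold higher number from compound 3 to compound 4 (1.39 log units; beyond the scatter), whereas a 1.6-fold higher number from compound 2 to compound 4 (0.20 log units; within the scatter) and a 1.3-fold higher number from compound 1 to compound 4 (0.11 log units; within the scatter) both stay within the scatter. At this position, next to the ring sulfur, the plain phenyl of compound 3 therefore stands clear of all three other groups, and a ring nitrogen is no better tolerated here than a 4-chloro or 4-bromo substituent. Nothing measured explains this.

Going by these compounds, whether fluoro, methyl or methoxy on the phenyl would stay near compound 3 or fall with compound 4 remains open.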